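The source may report more compounds than this note shows. Statements on the series, on what has been measured and on what is new or still open speak of the compounds shown alone.

Compound 1 `COc1ccc(C2CC(=NO)CC(c3ccc(OC)cc3)N2C)cc1` gives 380000 nM in a functional assay, with a stated time of 30 min (on this read-out higher numbers stand for weaker inhibition and lower numbers for stronger inhibition), the highest number among the three compounds measured, although every gap to the others stays within the scatter. Compound 2 `COc1ccc(C2CC(=NOC(=O)c3ccc([N+](=O)[O-])cc3)CC(c3ccc(OC)cc3)N2C)cc1` gives 280000 nM in this assay, and compound 3 `COc1ccc(C2CC(=NOC(=O)c3cc([N+](=O)[O-])cc([N+](=O)[O-])c3)CC(c3ccc(OC)cc3)N2C)cc1` gives 312000 nM in this assay. Compound 4 `COc1ccc(C2CC(=NOC(=O)c3ccccc3O)CC(c3ccc(OC)cc3)N2C)cc1` differs from compound 1 by (2-hydroxyphenyl)carbonyl in place of hydrogen on an oxygen. The closest comparison is a 1.4-fold lower number from compound 1 to compound 2 (0.13 log units; within the scatter), where a nitro-bearing carbonyl group likewise replaced hydrogen on that oxygen; the further change a 1.1-fold higher number from compound 2 to compound 3 (0.05 log units; within the scatter) also stayed within the scatter. Neither step points to movement beyond the scatter in this assay, so for compound 4 the expected step is a 1.2-fold lower number from compound 1 to compound 4 (0.06 log units; within the scatter). Compound 4 is therefore estimated at 330000 nM, with a range from 150000 nM to 700000 nM.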

Compound 4, half-maximal inhibitory concentration: 29000 nM
Compound 4: middle estimate off by 11-fold (1.06 log units), on the high side, and the stated range ends above it.
By their numbers in this assay, from the lowest: compound 4; then compounds 2, 3 and 1 (each within the scatter of the next).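

For the compounds shown here, the oxygen on the double-bonded nitrogen tolerates more than the earlier compounds suggested: in this assay, (2-hydroxyphenyl)carbonyl in place of hydrogen gives a 13-fold lower number from compound 1 to compound 4 (1.12 log units; beyond the scatter), a step beyond the scatter. Changing only the group on the carbonyl carbon also gives an 11-fold lower number from compound 3 to compound 4 (1.03 log units; beyond the scatter) and a 9.7-fold lower number from compound 2 to compound 4 (0.98 log units; beyond the scatter), so the carbonyl link alone does not account for the shift. No measurement here explains why this group differs from the nitro-bearing ones. Still open, going by these compounds, is whether the hydroxy matters, which plain phenyl, or an amine or carboxylic acid in place of that hydroxy, would test.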